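The compounds below may be only part of what the source reports. "The series", "measured", "known", "first", "only" and "open" are said of these compounds alone.

Compound 1 `Cc1ccc2occ(C(=O)Nc3cccc(Cl)c3)c(=O)c2c1`: 4.2 nM in an assay on cells for inhibition of Amine oxidase [flavin-containing] B (Homo sapiens), read by fluorescence and Amplex Red, using microsomes, with a stated time of 15 min; on this read-out higher numbers stand for weaker inhibition and lower numbers for stronger inhibition
Compound 2 `Cc1ccc2occ(C(=O)Nc3ccc(O)cc3)c(=O)c2c1`: 513 nM

Compound 1 gives the lower of the two numbers. Among the measured compounds shown here, the single measured step, a 120-fold higher number from compound 1 to compound 2 (2.09 log units; beyond the scatter), comes from 4-hydroxyphenyl in place of 3-chlorophenyl on an amide-type nitrogen. Compound 3 `COc1ccc2occ(C(=O)Nc3cccc(Cl)c3)c(=O)c2c1` differs from compound 1 by methoxy in place of methyl on an aromatic carbon. This change sits on the shared core, not on the amide-type nitrogen, so the measured step does not bear on it directly. Compound 3 is therefore expected to stay close to compound 1, a step of a 1.4-fold higher number from compound 1 to compound 3 (0.15 log units; within the scatter) within the scatter. The estimate for compound 3 is 6 nM, ranging from 2 nM to 25 nM.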

Compound 3, half-maximal inhibitory concentration: 3.94 nM
Compound 3: middle estimate off by 1.5-fold (0.18 log units), on the high side; low and high end bracket the measured number.
By their numbers in this assay, from the lowest: compounds 3 and 1 (each within the scatter of the next); then compound 2.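

Methoxy in place of methyl on this aromatic carbon of the shared core gives a 1.1-fold lower number from compound 1 to compound 3 (0.03 log units; within the scatter) in this assay and so adds an oxygen atom without moving the number beyond the scatter. The earlier step concerned only the group on the amide-type nitrogen and said nothing about this position. No measurement offered here explains why methyl and methoxy read alike.

From the compounds shown here alone, whether an amine, a carboxylic acid or a longer chain such as butoxy would fit this position equally well stays open. So does whether methoxy would read the same alongside the 4-hydroxyphenyl of compound 2.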